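Lengthening the chain of compound 2 by propyl

The source may report more compounds than this note shows. Statements on the series, on what has been measured and on what is new or still open speak of the compounds shown alone.

Compound 1 `CCCCCCCCc1cn(C/C=C(/C)CCC=C(C)C)nn1`: 6.92
Compound 2 `CCCCCc1cn(CC=C(C)C)nn1`: 3.46

In a physicochemical assay for lipophilicity, measured as octanol-water partition (a higher number here means a more lipophilic compound, a lower number a more polar compound), compound 2, at 3.46, holds the lower of the two measured numbers, and compound 1 gives 6.92, a gap beyond the scatter. Compound 3 `CCCCCCCCc1cn(CC=C(C)C)nn1` has not yet been measured. It differs from compound 2 in one place, propyl in place of hydrogen on a saturated chain carbon, five bonds along the chain from an aromatic carbon. For the measured compounds named here, no measured pair differs in a single place, so this step has no direct precedent. In this assay, a rise beyond the scatter is expected, smaller than the gap separating compound 2 from compound 1. The expected change is a number 1.44 log units higher from compound 2 to compound 3 (beyond the scatter). Compound 3 is estimated at 4.9, with an expected range of 4.5 to 5.3.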

Compound 3, partition coefficient: 4.92
The estimate for compound 3 lay 0.02 log units below the measured number, and the stated range covers the measured number.
By their numbers in this assay, from the lowest: compound 2; then compound 3; then compound 1.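

In this assay, for the compounds shown here, propyl in place of hydrogen on a saturated chain carbon, five bonds along the chain from an aromatic carbon, gives a number 1.46 log units higher from compound 2 to compound 3 (beyond the scatter), the first reading of a single change at this place. Compound 3 also links to compound 1: hydrogen in place of 3-methylbut-2-en-1-yl on a saturated chain carbon bound to a double-bonded chain carbon gives a number 2.00 log units lower from compound 1 to compound 3 (beyond the scatter), so each of the two changes, taken alone, moves the number beyond the scatter. No measurement given here bears on why either step has its size.

On these data alone, whether the number keeps rising with a longer chain, or how an amine or a carboxylic acid on that chain would read, stays open. As far as these compounds go, with one step at each place, it also remains unknown whether either step depends on the group present at the other place.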